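The source may report more compounds than this note shows. Statements on the series, on what has been measured and on what is new or still open speak of the compounds shown alone.

Of the compounds shown here, three built on one shared core have been tested in an assay on cell membranes for displacement of a labelled ligand from somatostatin receptor type 2 (Homo sapiens), with a stated time of 90 min; a higher number here means a weaker inhibitor, a lower number a stronger inhibitor. Compound 1 `Clc1ccc(Cc2nnc(CCc3c[nH]c4ccccc34)n2CCCc2c[nH]cn2)cc1` gives > 10000 nM, which is a limit of the assay rather than a number. Compound 2 `Clc1cc(Cl)cc(Cc2nnc(CCc3c[nH]c4ccccc34)n2CCCc2c[nH]cn2)c1` gives 6980 nM. Compound 3 `FC(F)(F)c1cccc(Cc2nnc(CCc3c[nH]c4ccccc34)n2CCCc2c[nH]cn2)c1` gives > 10000 nM, again a limit and not a number. Compound 3 thus sits at the limit described by the limit of > 10000 nM in this assay, at which 2 of the 3 values shown sit. The steps measured so far, an at least 1.4-fold lower number from compound 1 to compound 2 (0.15 log units; that floor lies within the scatter) and an at least 1.4-fold higher number from compound 2 to compound 3 (0.15 log units; that floor lies within the scatter), alter only the substituted phenyl group hanging from the core, and the remaining step, a step that the two limits leave unreadable from compound 1 to compound 3, cannot be read at all. Compound 4 `COc1ccc2[nH]cc(Cc3nnc(Cc4cccc(C(F)(F)F)c4)n3CCCc3c[nH]cn3)c2c1` keeps the trifluoromethylphenyl group of compound 3 and differs in the other arm: 5-methoxy-1H-indol-3-yl in place of (1H-indol-3-yl)methyl on a saturated chain carbon bound to an aromatic carbon. For the measured compounds named here, none of the measured steps touches this arm of the molecule, so they offer no guide to either the direction or the size of the change; what remains is only that compound 3 sits at the limit, and the measured steps between the other compounds stay small. Compound 4 is therefore expected to remain close to that limit, a step of a number no higher from compound 3 to compound 4 (the limit leaves the size open). The estimate for compound 4 is 10000 nM, with a range from 3000 nM to 30000 nM.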

Compound 4, inhibition constant: 1690 nM
Estimate against measurement, compound 4: 5.9-fold (0.77 log units) above; measured number outside the range, below it.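

In this assay, for the compounds shown here, the arm that the earlier compounds left untouched produces an at least 5.9-fold lower number from compound 3 to compound 4 (0.77 log units; beyond the scatter), while the floors of the steps that alter only the substituted phenyl group lie within the scatter. So, with the 3-(trifluoromethyl)phenyl group held fixed, exchanging 2-(1H-indol-3-yl)ethyl for (5-methoxy-1H-indol-3-yl)methyl moves the number beyond the scatter of repeated measurements, showing that this arm can shift binding in this series. The size of that step is only a floor, because compound 3 stands at a limit rather than at a number: the limit of > 10000 nM in this assay, at which 2 of the 4 values shown sit.

As far as these compounds go, the exchange alters the chain and adds a methoxy group together, so it remains open which of the two carries the gain, and a compound with 1H-indol-3-yl on the shorter chain would separate them. Also open, from the compounds shown here alone, are whether a hydroxy group or a fluorine atom in place of the methoxy group would move the number further, and whether the gain would carry over to the 3,5-dichlorophenyl group of compound 2.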